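Replacing 3,4-dichlorophenyl with 4-methoxyphenyl in compound 3

A few compounds are considered here, and "the series" means these few. Any claim that something is new, unique, unknown or untested is made for them only; others in the source may bear on it.

Three related compounds share one core and differ in the aromatic group on a carbon with a double bond to nitrogen. In a functional assay on PC-3 cells (Homo sapiens) for antiproliferative activity, read by MTT assay, with a stated time of 72 h (on this read-out higher numbers stand for weaker inhibition and lower numbers for stronger inhibition), compound 1 `O=C(N/N=C/c1ccc(Br)cc1)Nc1ccc(Oc2ccnc3[nH]ccc23)c(F)c1`, with 4-bromophenyl, gives 920 nM, compound 2 `O=C(N/N=C/c1ccc(F)cc1)Nc1ccc(Oc2ccnc3[nH]ccc23)c(F)c1`, with 4-fluorophenyl, gives 2330 nM, and compound 3 `O=C(N/N=C/c1ccc(Cl)c(Cl)c1)Nc1ccc(Oc2ccnc3[nH]ccc23)c(F)c1`, with 3,4-dichlorophenyl, gives 14100 nM. Compound 3 therefore has the highest number and is the weakest of the three.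

Compound 4 `COc1ccc(/C=N/NC(=O)Nc2ccc(Oc3ccnc4[nH]ccc34)c(F)c2)cc1` carries 4-methoxyphenyl in place of 3,4-dichlorophenyl on a carbon with a double bond to nitrogen. Within the data shown here, three measured steps bear on this change. Moving to 3,4-dichlorophenyl raised the number both times: a 15-fold higher number from compound 1 to compound 3 (1.19 log units; beyond the scatter) is large and a 6.1-fold higher number from compound 2 to compound 3 (0.78 log units; beyond the scatter) is modest. The change from bromo to fluoro gave a modest 2.5-fold higher number from compound 1 to compound 2 (0.40 log units; beyond the scatter). Among the measured compounds shown here, the name 4-methoxyphenyl reads more like the groups of compound 1 and compound 2 than that of compound 3, but no measured compound carries a methoxy group, so this is only a loose guide.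

A clear drop in the number is therefore expected, and the estimated step is a 4.7-fold lower number from compound 3 to compound 4 (0.67 log units; beyond the scatter). For compound 4 the expected value is 3000 nM, with an estimated range of 900 nM to 10000 nM.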

Compound 4, half-maximal inhibitory concentration: 6730 nM
The estimate for compound 4 lay 2.2-fold (0.35 log units) below the measured number, within the range that was stated.
By their numbers in this assay, from the lowest: compound 1; then compound 2; then compound 4; then compound 3.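

Among these compounds, the first non-halogen group at this position gives only a partial recovery in this assay (a 2.1-fold lower number from compound 3 to compound 4 (0.32 log units; beyond the scatter)), so a group of the same heavy-atom count as 3,4-dichlorophenyl and with one hydrogen-bond acceptor still gives a measurably different number. That recovery stops short of the two compounds with a single halogen, since methoxy on the aromatic carbon compares unfavourably with fluoro (a 2.9-fold higher number from compound 2 to compound 4 (0.46 log units; beyond the scatter)) and more so with bromo (a 7.3-fold higher number from compound 1 to compound 4 (0.86 log units; beyond the scatter)), which gives the order bromo, fluoro, methoxy among these singly substituted rings, with compound 3 still the highest number of all. Nothing shown explains why these groups rank this way.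

The compounds shown leave open whether 4-chlorophenyl would sit with compound 1 and compound 2 or closer to compound 3, which would help separate the effect of the second chlorine from that of chlorine itself. They also leave open how an unsubstituted phenyl, a dimethylamino group or a carboxylic acid on the ring would compare with bromo and methoxy in this assay.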